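Para-substituent variation on the shared oxazolyl ketone core

The source may report more compounds than this note shows. Statements on the series, on what has been measured and on what is new or still open speak of the compounds shown alone.

Measured compounds in an assay (Rattus norvegicus) for inhibition of Fatty-acid amide hydrolase 1 (Homo sapiens); on this read-out lower numbers stand for stronger inhibition and higher numbers for weaker inhibition:
compound 1 `Nc1ccc(-c2cnc(C(=O)CCCCCCc3ccccc3)o2)cc1` gives 90 nM
compound 2 `O=C(O)c1ccc(-c2cnc(C(=O)CCCCCCc3ccccc3)o2)cc1` gives 60 nM
compound 3 `O=C(CCCCCCc1ccccc1)c1ncc(-c2ccc(O)cc2)o1` gives 140 nM

Compound 3 shows the highest of the three numbers. Its nearest neighbour is compound 1, a 1.6-fold higher number from compound 1 to compound 3 (0.19 log units; within the scatter); the larger separation is to compound 2, a 2.3-fold higher number from compound 2 to compound 3 (0.37 log units; beyond the scatter). Compound 1 and compound 2 are close to each other, a 1.5-fold lower number from compound 1 to compound 2 (0.18 log units; within the scatter).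

Compound 4 `NS(=O)(=O)c1ccc(-c2cnc(C(=O)CCCCCCc3ccccc3)o2)cc1` carries a change at the same point of the shared core: sulfamoyl in place of hydroxy on an aromatic carbon. The three measured steps all exchange the substituent at this one position, para to a large group, among amino, carboxy and hydroxy, and all stay within a modest span; only the carboxy-to-hydroxy step exceeded the scatter. Sulfamoyl has not been measured here, so the expectation rests on that span alone: a position that tolerates amino, carboxy and hydroxy with small movement is expected to place sulfamoyl in the same region, likely somewhat lower than compound 3 since compound 2 gives 60 nM with a comparable donor-and-acceptor group.

Compound 4 is therefore estimated at 90 nM in this assay, range 40 nM to 250 nM, meaning an expected step of a 1.6-fold lower number from compound 3 to compound 4 (0.19 log units; within the scatter).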

Compound 4, inhibition constant: 10 nM
Estimate against measurement, compound 4: 9.0-fold (0.95 log units) above; the whole stated range lies above it.
By their numbers in this assay, from the lowest: compound 4; then compounds 2, 1 and 3 (each within the scatter of the next, the first and the last beyond it).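

Sulfamoyl shows that this position, para to a large group, is not as flat as amino, carboxy and hydroxy suggested in this assay: the change gives a 14-fold lower number from compound 3 to compound 4 (1.15 log units; beyond the scatter), and the other two comparisons give a 9.0-fold lower number from compound 1 to compound 4 (0.95 log units; beyond the scatter) and a 6.0-fold lower number from compound 2 to compound 4 (0.78 log units; beyond the scatter). All three steps lie beyond the scatter, so compound 4 stands apart from every earlier member of the series, whereas the earlier substituents differed from each other by little or, in two of their three steps, by no more than the scatter. Hydroxy and sulfamoyl have the same count of hydrogen-bond donors, while sulfamoyl brings more heavy atoms and hydrogen-bond acceptors, but nothing available here ties the step to any of these differences.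

The compounds shown leave open whether a methylsulfonyl group, an N-methylsulfamoyl group or a carboxamide at this position would give a number close to that of compound 4 or one closer to those of compounds 1, 2 and 3. Also open, from the compounds shown here alone, is whether the same step from hydroxy to sulfamoyl would appear with a shorter chain on the shared core.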